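Swapping a hydroxyphenyl isomer on a shared pyridine core

The source may hold more compounds than are shown below. What is called first, only, known or untested is meant among the compounds shown, and "the series" means these compounds.

Compound 1 `Oc1ccc(-c2cc(-c3ccco3)cc(-c3ccccc3O)n2)cc1`: > 50000 nM
Compound 2 `Oc1ccc(-c2cc(-c3ccco3)cc(-c3cccc(O)c3)n2)cc1`: 2070 nM
Compound 3 `Oc1cccc(-c2cc(-c3cccnc3)cc(-c3ccccc3O)n2)c1`: 5580 nM

In a functional assay on DU-145 cells (Homo sapiens) for cytotoxicity, read by CCK-8 assay (on this read-out lower numbers stand for stronger inhibition and higher numbers for weaker inhibition), compound 1 reaches only a limit, (the limit of > 50000 nM in this assay, at which 1 of the 3 values shown sits). Compound 2 gives 2070 nM in this assay, and the change 3-hydroxyphenyl in place of 2-hydroxyphenyl on an aromatic carbon brings an at least 24-fold lower number from compound 1 to compound 2 (1.38 log units; beyond the scatter). Compound 3 gives 5580 nM in this assay; how its core differs from that of compound 1 is not broken down here. Compound 4 `Oc1cccc(-c2cc(-c3cccnc3)cc(-c3cccc(O)c3)n2)c1` carries the same kind of change, (3-hydroxyphenyl in place of 2-hydroxyphenyl on an aromatic carbon), though here the place is meta to a 3-hydroxyphenyl group and meta to a pyridin-3-yl group rather than meta to a 4-hydroxyphenyl group and a furan-2-yl group. Because an at least 24-fold lower number from compound 1 to compound 2 (1.38 log units; beyond the scatter) was large, a similar drop is expected for compound 4, estimated as an 11-fold lower number from compound 3 to compound 4 (1.05 log units; beyond the scatter). Compound 4 is expected to give about 500 nM in this assay, between 100 nM and 3000 nM.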

Compound 4, half-maximal inhibitory concentration: > 50000 nM
Compound 4 was reported as a limit; the forecaster's own chance of this, stated with the estimate: 5%; at least 100-fold (2.00 log units) between middle value and limit.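

In this assay compound 4 gives > 50000 nM, which is a limit of the assay and not a number. The swap of 2-hydroxyphenyl for 3-hydroxyphenyl brings an at least 8.9-fold higher number from compound 3 to compound 4 (0.95 log units; beyond the scatter), so the change did not carry from the core of compound 1 to the core of compound 3, and its direction reversed: the same change on two cores in this assay, an at least 24-fold lower number (1.38 log units; beyond the scatter) from compound 1 to compound 2 and an at least 8.9-fold higher number (0.95 log units; beyond the scatter) from compound 3 to compound 4, at least 210-fold (2.33 log units) apart, beyond the scatter of two such steps This shows that the outcome of the swap depends on the core in these two pairs, but it does not show which feature of the cores is responsible.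

Open, as far as these compounds go, is whether the furan-2-yl or pyridin-3-yl group, or the position of the other hydroxyl group, decides the direction. Also open, from the compounds shown here alone, is how an amine or a carboxylic acid in place of the hydroxyl group would read in this assay.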